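The compounds below may be only part of what the source reports. "The series", "measured", "known", "first", "only" and "open" are said of these compounds alone.

Measured compounds in an assay on CHO-K1 cells for displacement of a labelled ligand from prostaglandin E2 receptor EP1 subtype (Homo sapiens); a higher number here means a weaker inhibitor, a lower number a stronger inhibitor:

compound 1 `Cc1cc(C(=O)NCc2ccccc2)nn1Cc1cc(Cl)ccc1OCc1ccccc1` gives 39.8 nM
compound 2 `Cc1cc(C(=O)NCc2ccncc2)nn1Cc1cc(Cl)ccc1OCc1ccccc1` gives 79.4 nM
compound 3 `Cc1cc(NC(=O)C2CCCC2)nn1Cc1cc(Cl)ccc1OCc1ccccc1` gives 15.9 nM

Compound 3 stands at the lowest number of the three in this assay and is the strongest binder shown: the steps to it are a 2.5-fold lower number from compound 1 to compound 3 (0.40 log units; beyond the scatter) and a 5.0-fold lower number from compound 2 to compound 3 (0.70 log units; beyond the scatter), both beyond the scatter. Compound 1 and compound 2 sit within the scatter of each other, a 2.0-fold higher number from compound 1 to compound 2 (0.30 log units; within the scatter).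

Compound 4 `Cc1cc(NC(=O)C2CCCO2)nn1Cc1cc(Cl)ccc1OCc1ccccc1` differs from compound 3 in one place: oxolan-2-yl in place of cyclopentyl on a carbonyl carbon. Among the compounds with values here, no measured step exchanges one saturated ring for another, so none bears directly on this change. Within the data shown here, the only step that swaps a ring for a ring carrying one hetero atom, a 2.0-fold higher number from compound 1 to compound 2 (0.30 log units; within the scatter), lies within the scatter, and it sits on a different part of the molecule. On that thin basis the expected change in this assay is small, if anything toward a slightly higher number, and may well stay within the scatter.

Compound 4 is therefore estimated at 25 nM, with a range from 8 nM to 80 nM. The step this estimate means is a 1.6-fold higher number from compound 3 to compound 4 (0.20 log units; within the scatter), expected to stay within the scatter.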

Compound 4, half-maximal inhibitory concentration: 39.8 nM
Estimate against measurement, compound 4: 1.6-fold (0.20 log units) below, within the range that was stated.
By their numbers in this assay, from the lowest: compound 3; then compounds 1, 4 and 2 (each within the scatter of the next).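

In this assay, within the data shown here, the ring on the carbonyl carbon does register: oxolan-2-yl in place of cyclopentyl gives a 2.5-fold higher number from compound 3 to compound 4 (0.40 log units; beyond the scatter), the only measured step that exchanges one saturated ring for another, modest but beyond the scatter. With the heavy-atom count unchanged and one ring carbon replaced by oxygen, compound 4 no longer stands apart from the two carbamoyl compounds: the steps are no change at the digits printed from compound 1 to compound 4 (within the scatter) and a 2.0-fold lower number from compound 2 to compound 4 (0.30 log units; within the scatter), both within the scatter. Nothing measured here accounts for the step.

Open, as far as these compounds go, is whether the step follows the ring oxygen itself or its place in the ring: oxolan-3-yl or pyrrolidin-2-yl on the same carbonyl carbon would separate these. Also open, from the compounds shown here alone, is how cyclohexyl or an open n-butyl chain would compare with compound 3 at 15.9 nM on that carbon.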